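Fluoro in place of dimethylamino on the benzyl group

The source may hold more compounds than are shown below. What is called first, only, known or untested is meant among the compounds shown, and "the series" means these compounds.

compound 1 `O=C(Nc1c(F)cc(F)cc1F)N(Cc1cccc(-c2cc[nH]n2)c1)C1CCCCCC1`: 0.062 mg/kg
compound 2 `CN(C)c1ccc(CN(Cc2cccc(-c3cc[nH]n3)c2)C(=O)Nc2c(F)cc(F)cc2F)cc1`: < 0.32 mg/kg

In a functional assay on a cell-free system (plasma) with sterol O-acyltransferase, Soat (Rattus norvegicus) as the target (a higher number here means that more compound is needed for the effect, a lower number that less compound is needed), compound 1 gives 0.062 mg/kg. For compound 2 only a limit of the assay is known, namely < 0.32 mg/kg. That limit is the limit of < 0.32 mg/kg in this assay, at which 1 of the 2 values shown sits. Among the measured compounds shown here, the one measured step, a step that the limit leaves unreadable from compound 1 to compound 2, therefore carries no readable size. Compound 3 `O=C(Nc1c(F)cc(F)cc1F)N(Cc1ccc(F)cc1)Cc1cccc(-c2cc[nH]n2)c1` differs from compound 2 by fluoro in place of dimethylamino on an aromatic carbon. For the measured compounds named here, no measured step touches this exchange, so neither direction nor size can be drawn from the data. Compound 3 is expected to give 0.12 mg/kg in this assay, within a range of 0.02 mg/kg to 0.7 mg/kg, which means an expected step that the limit leaves unreadable from compound 2 to compound 3.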

Compound 3, dose for half-maximal effect: < 0.32 mg/kg
Compound 3 was reported as a limit; the forecaster's own chance of this, stated with the estimate: 30%; the middle value lies beyond the limit too.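

Compound 3 is reported only as a limit, < 0.32 mg/kg, so no step among compound 1, compound 2 and compound 3 can be read: the limit of < 0.32 mg/kg in this assay, at which 2 of the 3 values shown sit.

From the compounds shown here alone, how 4-fluorobenzyl, 4-(dimethylamino)benzyl and cycloheptyl rank in this assay stays open.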